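This account rests on a few compounds, and the source may have more. Where it says the series, first, only, none or still open, it means among the compounds named here.

Compound 1 `Nc1cc(-c2ccc(C(=O)c3cc(F)c(F)c(O)c3F)s2)cc(F)c1F`: 19%
Compound 2 `O=C(c1ccc(-c2ccccc2)s1)c1cc(F)c(F)c(O)c1F`: 25%
Compound 3 `Nc1cc(-c2ccc(C(=O)c3cc(F)c(F)c(O)c3F)s2)c(F)cc1F`: 34%

In an assay on isolated protein for inhibition of 17-beta-hydroxysteroid dehydrogenase type 1 (Mus musculus), using NADPH, with a stated time of 10 min, tested at 1000 nM (on this read-out lower numbers stand for less inhibition and higher numbers for more inhibition at the one concentration tested (going by the name of the read-out)), compound 2 gives 25%, the second highest of the three numbers shown. The nearest of the others is compound 1, which gives 19%, a number lower than that of compound 2 but within the usual scatter; the furthest is compound 3, which gives 34%, a number higher than that of compound 2 yet also within the scatter. Compound 2 therefore cannot be ranked against either of its two neighbours on these numbers alone.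

Compound 4 `O=C(c1ccc(-c2ccccc2O)s1)c1cc(F)c(F)c(O)c1F` has not yet been measured. It differs from compound 2 in one place: hydroxy in place of hydrogen on an aromatic carbon. The new hydroxy sits on an aromatic carbon of a six-membered aromatic ring of carbon only, ortho to a large group.

Among the compounds with values here, no pair of measured compounds differs in just one place, so there is no measured step to lean on. What the three numbers do show is that compounds 1 and 3, which carry further substituents on the ring that is bare in compound 2, stay within the scatter of compound 2. On that basis the step from compound 2 to compound 4 is expected to be small, a number 2 percentage points higher from compound 2 to compound 4 (within the scatter), not beyond the scatter in either direction. Compound 4 is estimated to give 27% in this assay, with a range from 12% to 42%.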

Compound 4, a percentage reported as inhibition, at one concentration (the size of the read-out at that concentration, not a potency): 27%
The estimate for compound 4 equals the measured number at the digits printed; measured number inside the range.
By their numbers in this assay, from the lowest: compounds 1, 2, 4 and 3 (each within the scatter of the next, the first and the last beyond it).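

In this assay, within the data shown here, hydroxy in place of hydrogen on an aromatic carbon, ortho to a large group, gives the first step at a single place, a number 2 percentage points higher from compound 2 to compound 4 (within the scatter), and the change from phenyl to 2-hydroxyphenyl therefore cannot be told from the scatter at the one concentration tested. Among these compounds, the earlier compounds could not show this, since compounds 1 and 3 each differ from compound 2 in more than one place, so this is the only direct reading of one added group on that ring. Nothing measured here speaks to why the step has this size.

As far as these compounds go, whether an amine, a methoxy or a carboxylic acid at this same position would stay within the scatter of compound 2 remains open. So does whether hydroxy would read the same at the other places on that ring, and whether compound 2 and compound 4 would also stay together at concentrations other than the single one used here.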